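The source may hold more compounds than are shown below. What is called first, only, known or untested is meant among the compounds shown, and "the series" means these compounds.

Series notes, step from compound 3 to compound 4.

Compound 3 `O=C(C[C@H](NC(=O)c1cc2ccccc2cn1)C(=O)OCc1ccccc1)OCc1ccccc1` gives 37.5% in a functional assay on the whole organism (CCRF S-180 cells, Mus musculus) for inhibition, in a xenograft, with stated times of 7 days and 24 h, at a dose of 100 umol/kg by the intraperitoneal route; a lower number here means less inhibition, a higher number more inhibition at the dose given (going by the name of the read-out). Of the three numbers shown, compound 3 sits between the other two, with both gaps within the scatter. Compound 1 `NC(=O)C[C@H](NC(=O)c1cc2ccccc2cn1)C(=O)OCc1ccccc1` gives 36.7% in this assay, and the step of a number 0.8 percentage points higher from compound 1 to compound 3 (within the scatter) is within the scatter. Compound 2 `CSCC[C@H](NC(=O)c1cc2ccccc2cn1)C(=O)OCc1ccccc1` gives 39.6% in this assay, and the step of a number 2.1 percentage points lower from compound 2 to compound 3 (within the scatter) is likewise within the scatter. The remaining pair, a number 2.9 percentage points higher from compound 1 to compound 2 (within the scatter), is also within the scatter, so the three measured compounds are indistinguishable in this assay at the dose used.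

Compound 4 `NCCCC[C@H](NC(=O)c1cc2ccccc2cn1)C(=O)OCc1ccccc1` is not yet measured. The change from compound 3 is 3-aminopropyl in place of benzyloxycarbonyl on a saturated chain carbon, two bonds along the chain from an amide-type nitrogen and a carbonyl carbon.

For the measured compounds named here, the steps that bear on this change are the two at the same saturated chain carbon, a number 2.9 percentage points higher from compound 1 to compound 2 (within the scatter) and a number 2.1 percentage points lower from compound 2 to compound 3 (within the scatter), and the step of a number 0.8 percentage points higher from compound 1 to compound 3 (within the scatter) on the carbonyl carbon. All three exchanges at this position, among groups of quite different size and hydrogen-bonding count, left the read-out within the scatter. On this basis compound 4 is expected to show no step beyond the scatter, a number 0.5 percentage points higher from compound 3 to compound 4 (within the scatter), in either direction.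

Estimate for compound 4 in this assay: 38%, expected to lie between 26% and 50%.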

Compound 4, a percentage reported as inhibition, in the whole organism at one dose (the size of the read-out at that dose, not a potency): 40.6%
The estimate for compound 4 lay 2.6 percentage points below the measured number, within the range that was stated.
By their numbers in this assay, from the lowest: compounds 1, 3, 2 and 4 (each within the scatter of the next).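

In this assay, compound 4 puts a chain ending in an amine on the saturated chain carbon, two bonds along the chain from an amide-type nitrogen and a carbonyl carbon, and the steps of a number 3.1 percentage points higher from compound 3 to compound 4 (within the scatter) and a number 1 percentage points higher from compound 2 to compound 4 (within the scatter) and a number 3.9 percentage points higher from compound 1 to compound 4 (within the scatter) all remain within the scatter. Where the earlier exchanges at this place involved only carbamoyl, (methylsulfanyl)methyl and benzyloxycarbonyl, the read-out at this dose now also fails to separate any of these from 3-aminopropyl, a group with no ring, so even the loss of the six-membered aromatic ring of benzyloxycarbonyl leaves no step beyond the scatter. Nothing available accounts for this flat picture.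

The compounds shown leave open whether a carboxylic acid or a guanidine at the end of this chain, or a longer chain, would give a step beyond the scatter in this assay. They also leave open whether replacing the benzyl ester shared by all four compounds would change the read-out, and whether these compounds would separate at other doses.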